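Fluoro added to the aniline ring in the MCF7 series

The source may hold more compounds than are shown below. What is called first, only, known or untested is meant among the compounds shown, and "the series" means these compounds.

Measured so far:
compound 1 `CCS(=O)(=O)Nc1cc(-c2ccc3ncnc(Nc4ccc(F)cc4F)c3c2)cnc1OC`: 1610 nM
compound 2 `CCS(=O)(=O)Nc1cc(-c2ccc3ncnc(Nc4cccc(C(=O)OC)c4)c3c2)cnc1OC`: 10100 nM

In a functional assay on MCF7 cells (Homo sapiens) for cytotoxicity, read by sulforhodamine B assay, with a stated time of 72 h (a lower number here means a stronger inhibitor, a higher number a weaker inhibitor), compound 2 stands highest of the two numbers; the nearest is compound 1, reached by a 6.3-fold higher number from compound 1 to compound 2 (0.80 log units; beyond the scatter) through a change of the whole aryl group. Compound 3 `CCS(=O)(=O)Nc1cc(-c2ccc3ncnc(Nc4ccc(F)c(C(=O)OC)c4)c3c2)cnc1OC` differs from compound 2 by fluoro in place of hydrogen on an aromatic carbon. Within the data shown here, no measured step isolates this single added fluoro, so the prior rests on compound 1 alone, which carries fluoro at a ring position para to the large group and gives 1610 nM. Compound 3 is therefore expected to show a 1.4-fold lower number from compound 2 to compound 3 (0.16 log units; within the scatter), a slight move downward at most. The estimate for compound 3 is 7000 nM, range 3000 nM to 16000 nM.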

Compound 3, half-maximal inhibitory concentration: 1150 nM
Compound 3: the middle estimate sits 6.1-fold (0.78 log units) above what was measured, and the stated range ends above it.
By their numbers in this assay, from the lowest: compounds 3 and 1 (each within the scatter of the next); then compound 2.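

In this assay, fluoro on the aromatic carbon ortho to the methoxycarbonyl group and para to a large group gives an 8.8-fold lower number from compound 2 to compound 3 (0.94 log units; beyond the scatter) and so has a clear effect at this position, a single added atom sufficing. With that fluoro present, the ring change leaves the two aryl groups unseparated, with a 1.4-fold lower number from compound 1 to compound 3 (0.15 log units; within the scatter). Nothing available accounts for the effect of the fluoro.

On these data alone, whether this step is specific to fluoro remains open, as chloro or methoxy at this carbon would show. Also open, as far as these compounds go, is whether it persists when a carboxylic acid replaces the methoxycarbonyl group.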